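Acid replaced by dimethylamide: a potency loss expected

This account rests on a few compounds, and the source may have more. Where it says the series, first, only, none or still open, it means among the compounds named here.

Compound 1 `CCCCN(c1nc2c(C(=O)O)cccc2o1)[C@H](C)c1ccc(-c2ccccc2-c2nnn[nH]2)cc1` is the reference point in this set. In a functional assay on CAL1 cells for inhibition of chemerin-like receptor 1 (Homo sapiens), with a stated time of 45 min (on this read-out lower numbers stand for stronger inhibition and higher numbers for weaker inhibition), compound 1 gives 17 nM, the highest of the three numbers shown. Compound 2 `Cc1ccc(-c2nc(=O)o[nH]2)c(-c2ccc([C@@H](C)N(CC3CC3)c3nc4c(C(=O)O)cccc4o3)cc2)c1` gives 3.2 nM in this assay, and compound 3 `CCCCN(c1nc2c(C(=O)O)cccc2o1)[C@H](C)c1ccc(-c2cc(Cl)ccc2-c2nc(=O)o[nH]2)cc1` gives 1.2 nM; both stand beyond the scatter from compound 1, with compound 3 the furthest away. Going by the values given here, no pair among the measured compounds differs in a single place, so no counted step is available for any of them; compound 2 and compound 3 each alter more than one part relative to compound 1.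

Compound 4 `CCCCN(c1nc2c(C(=O)N(C)C)cccc2o1)[C@H](C)c1ccc(-c2ccccc2-c2nnn[nH]2)cc1` is not yet measured. Relative to compound 1 the change is dimethylamino in place of hydroxy on a carbonyl carbon, or, read one bond further out, carboxy to dimethylcarbamoyl. Nothing in the measured set tests this change; all three measured compounds keep the carboxy group and vary only elsewhere, so the expectation is not anchored by any measured step. The expected step from compound 1 to compound 4 is an 8.8-fold higher number from compound 1 to compound 4 (0.95 log units; beyond the scatter), a move to a higher number beyond the scatter. Compound 4 is expected at 150 nM in this assay, within 30 nM to 800 nM.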

Compound 4, half-maximal inhibitory concentration: 13 nM
For compound 4 the middle estimate is 12-fold (1.06 log units) above the measured one; the measured number lies below the stated range.
By their numbers in this assay, from the lowest: compound 3; then compound 2; then compounds 4 and 1 (each within the scatter of the next).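

At this position, on a carbonyl carbon whose other neighbours are an aromatic carbon, this assay now gives a direct reading of carboxy to dimethylcarbamoyl: a 1.3-fold lower number from compound 1 to compound 4 (0.12 log units; within the scatter). Going by these compounds alone, compound 2 and compound 3 both keep the carboxy group, so only this pair tests the position, and it shows that on the background of compound 1 a carboxy group is not needed for a value in this range, even though compound 4 carries dimethylamino, counted with 0 hydrogen-bond donors, where compound 1 carries hydroxy, counted with 1 hydrogen-bond donor. No measurement at hand explains why the two compounds stand within the scatter of each other.

This single pair cannot say whether the same exchange would read alike on the backgrounds of compound 2 and compound 3, which differ from compound 1 elsewhere as well. Going by these compounds, how far the position tolerates other groups also stays open, for instance a primary carboxamide, a methyl ester, or a larger amide such as diethylcarbamoyl or pyrrolidine-1-carbonyl.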